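The compounds below may be only part of what the source reports. "The series", "measured", "known", "first", "only" and "open" are said of these compounds alone.

Compound 1, `CC(C)CNc1nc(N)nc2c1ncn2/C=C1/CC1(CO)CO`: in an ADME assay on HFF cells (Homo sapiens) for cytotoxicity, with a stated time of 8 days (a lower number here means that less compound is tolerated, a higher number that more compound is tolerated), compound 1 gives a limit of > 300000 nM.
Compound 2, `CCCCCOc1nc(N)nc2c1ncn2/C=C1/CC1(CO)CO`: in this assay compound 2 gives 259000 nM.
Compound 3, `CCCCNc1nc(N)nc2c1ncn2/C=C1/CC1(CO)CO`: in this assay compound 3 gives a limit of > 300000 nM.

Compound 3 thus stands at the edge of what this assay can report, and it shares that position with compound 1, as the limit of > 300000 nM in this assay, at which 2 of the 3 values shown sit, records. Only compound 2 yields a number. The steps among the three are small: an at least 1.1-fold lower number from compound 1 to compound 2 (0.06 log units; that floor lies within the scatter), an at least 1.1-fold higher number from compound 2 to compound 3 (0.06 log units; that floor lies within the scatter), and a step that the two limits leave unreadable from compound 1 to compound 3.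

The unmeasured compound 4, `Nc1nc(OCC(F)(F)F)c2ncn(/C=C3/CC3(CO)CO)c2n1`, differs from compound 3 by 2,2,2-trifluoroethoxy in place of butylamino on an aromatic carbon. Among the measured compounds shown here, the steps that bear on it are the two that trade an amino group for an alkoxy group on the same aromatic carbon, from compound 1 to compound 2 and from compound 2 to compound 3, and both fall within the scatter. Compound 4 is therefore expected to show no step beyond the scatter, an at least 1.0-fold lower number from compound 3 to compound 4 (0.02 log units; that floor lies within the scatter), with a fair chance that it again returns only a limit. The estimate for compound 4 in this assay is 280000 nM, within a range from 150000 nM to 300000 nM.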

Compound 4, half-maximal cytotoxic concentration: > 300000 nM
Compound 4: no number, only a limit; the forecaster's own chance of this, stated with the estimate: 55%; at least 1.0-fold (0.02 log units) between middle value and limit.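

Compound 4 gives a limit and not a number, so an oxygen-linked group on this aromatic carbon, next to the ring nitrogen, now stands at the same limit as the amino-linked groups of compound 1 and compound 3: the limit of > 300000 nM in this assay, at which 3 of the 4 values shown sit. Within the oxygen-linked pair, trifluoromethyl in place of butyl on the saturated chain carbon bound to the oxygen gives an at least 1.1-fold higher number from compound 2 to compound 4 (0.06 log units; that floor lies within the scatter), so this change is not shown to matter, though the limit leaves its true size open. The steps from compound 3 to compound 4 and from compound 1 to compound 4 cannot be read, as both ends of each are limits.

The compounds shown leave open how far each limit lies from the true value, and so whether the groups on this carbon differ at all in this assay. Going by these compounds, it also stays open whether a cyclic amine such as morpholine, a carboxylic acid or a much longer chain at this place would give a number clearly beyond the scatter from these compounds.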